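The source may report more compounds than this note shows. Statements on the series, on what has been measured and on what is new or still open speak of the compounds shown alone.

Measured in a functional assay on MT4 cells (Homo sapiens) for cytotoxicity; on this read-out higher numbers stand for lower toxicity in this test and lower numbers for higher toxicity in this test:
- compound 1 `COc1ccc(-c2c(C)nc(S)n2Nc2cccc(Cl)c2)cc1`: 38700 nM
- compound 2 `Cc1nc(S)n(Nc2cccc(Cl)c2)c1-c1ccc(Cl)cc1`: 40800 nM
- compound 3 `CC1N=C(S)N(Nc2cccc(Cl)c2)C1C(=O)O`: 266000 nM

In this assay, compound 2 and compound 1 lie within the scatter of each other, while compound 3 shows a higher number than either. The unmeasured compound 4 `Cc1nc(S)n(Nc2cccc(Cl)c2)c1-c1cccc(Cl)c1` has the same atoms as compound 2, joined differently, with 3-chlorophenyl in place of 4-chlorophenyl on an aromatic carbon.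

Among the compounds with values here, only one measured step bears on this change: a 1.1-fold higher number from compound 1 to compound 2 (0.02 log units; within the scatter). It also alters the aryl group at this place, though it swaps a substituent rather than shifting the chlorine. Within the data shown here, no measured pair tests the chlorine's position directly, so the evidence is indirect. Even so, with a 1.1-fold higher number from compound 1 to compound 2 (0.02 log units; within the scatter) as the only guide, no change beyond the scatter is expected in this assay, and no direction can be favoured. The expected step is a 1.0-fold lower number from compound 2 to compound 4 (0.01 log units; within the scatter). Compound 4 is estimated at 40000 nM, with an expected range from 20000 nM to 80000 nM.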

Compound 4, half-maximal cytotoxic concentration: 31000 nM
Beside the measured number, compound 4's estimate is 1.3-fold (0.11 log units) above it, within the range that was stated.
By their numbers in this assay, from the lowest: compounds 4, 1 and 2 (each within the scatter of the next); then compound 3.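

In this assay, moving the chlorine from 4-chlorophenyl to 3-chlorophenyl gives a 1.3-fold lower number from compound 2 to compound 4 (0.12 log units; within the scatter), so this shift of the chlorine leaves the number within the scatter. This pair tests the chlorine's position directly, which the earlier swap of chloro for methoxy on this aryl group could not do. Nothing measured here explains the result.

Going by these compounds, whether this aryl group tolerates larger changes at this place remains open, for example an amine on the ring or a longer alkyl chain in place of the ring. Compound 3 differs from the other compounds in more than one place, so the compounds shown also leave open which of its differences sets its number apart.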